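This account rests on a few compounds, and the source may have more. Where it says the series, first, only, none or still open, it means among the compounds named here.

Of the compounds shown here, two have been measured in a functional assay (aorta) for antagonist activity, with Oryctolagus cuniculus as the target (a lower number here means a stronger inhibitor, a higher number a weaker inhibitor), so far. Compound 1 `CCCCc1ccc(CN(C)S(=O)(=O)c2ccc(C)cc2)c(=O)n1Cc1ccc(-c2ccccc2-c2nn[nH]n2)cc1` gives 8 nM in this assay. Compound 2 `CCCCc1ccc(CN(Cc2ccccc2)S(C)(=O)=O)c(=O)n1Cc1ccc(-c2ccccc2-c2nn[nH]n2)cc1` gives 2 nM in this assay. Within the data shown here, the single recorded step, a 4.0-fold lower number from compound 1 to compound 2 (0.60 log units; beyond the scatter), is the only guide available, and it changed two things at once: the group on the sulfonyl and the group on the sulfonamide nitrogen. Among the measured compounds shown here, compound 2 therefore stands as the lower of the two numbers, with compound 1 as its only neighbour.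

Compound 3 `CCCCc1ccc(CN(CC)S(C)(=O)=O)c(=O)n1Cc1ccc(-c2ccccc2-c2nn[nH]n2)cc1` is the next compound. The change from compound 2 is methyl in place of phenyl on a saturated chain carbon bound to a sulfonamide nitrogen, so the benzyl on the sulfonamide nitrogen becomes ethyl while the methylsulfonyl is kept. For the measured compounds named here, no measured step isolates this change, and the step from compound 1 to compound 2 cannot be split into its two parts from the data. The expectation for compound 3 in this assay is therefore uncertain, with a step of a 2.5-fold higher number from compound 2 to compound 3 (0.40 log units; beyond the scatter) toward a somewhat higher number thought most likely. The estimate for compound 3 is 5 nM, with a range from 1.5 nM to 20 nM.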

Compound 3, half-maximal inhibitory concentration: 2 nM
Compound 3: the middle estimate sits 2.5-fold (0.40 log units) above what was measured; the range from low to high includes it.
By their numbers in this assay, from the lowest: compounds 2 and 3 (each within the scatter of the next); then compound 1.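

In this assay, putting ethyl in place of benzyl on the sulfonamide nitrogen gives no change at the digits printed from compound 2 to compound 3 (within the scatter), so at this position the phenyl and its six-membered aromatic ring can go with no change outside the usual scatter. The step of a 4.0-fold lower number from compound 1 to compound 3 (0.60 log units; beyond the scatter) is the same in size as a 4.0-fold lower number from compound 1 to compound 2 (0.60 log units; beyond the scatter), which shows that the lower number seen with compound 2 does not depend on having a benzyl on the nitrogen: ethyl with methylsulfonyl does just as well. Nothing measured here explains why these two groups read alike at this position.

The compounds shown leave open how far the group on the nitrogen can vary, for instance whether a longer chain such as hexyl, or a chain ending in a carboxylic acid, would keep the number where it is. They also leave open how much of the step away from compound 1 belongs to the group on the sulfonyl and how much to the group on the nitrogen, as no pair shown changes the sulfonyl group alone.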